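The compounds below may be only part of what the source reports. "The series", "measured", "known", "first", "only" and "open" are said of these compounds alone.

- compound 1 `Cc1ccc(N(C(=O)c2ccccc2[N+](=O)[O-])C(=S)OCCN2C(=O)c3ccccc3C2=O)cc1` gives 100000 nM
- compound 2 `Cc1ccc(N(C(=O)c2cccc([N+](=O)[O-])c2)C(=S)OCCN2C(=O)c3ccccc3C2=O)cc1` gives 100000 nM
- compound 3 `Cc1ccc(N(C(=O)c2cc(F)ccc2F)C(=S)OCCN2C(=O)c3ccccc3C2=O)cc1` gives 62000 nM

These three compounds were measured in an ADME assay on MT4 cells (Homo sapiens) for cytotoxicity, read by MTT assay; a higher number here means that more compound is tolerated, a lower number that less compound is tolerated. The value of compound 3, 62000 nM, lies within the usual scatter of the values of both compound 1 and compound 2. The next compound, compound 4 `Cc1ccc(N(C(=O)c2ccc(Cl)c(Cl)c2)C(=S)OCCN2C(=O)c3ccccc3C2=O)cc1`, differs from compound 3 in one place: 3,4-dichlorophenyl in place of 2,5-difluorophenyl on a carbonyl carbon. In words, 3,4-dichlorophenyl sits in place of 2,5-difluorophenyl on a carbonyl carbon.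

Three measured steps changed the group at this same place: no change at the digits printed from compound 1 to compound 2 (within the scatter), a 1.6-fold lower number from compound 1 to compound 3 (0.21 log units; within the scatter) and a 1.6-fold lower number from compound 2 to compound 3 (0.21 log units; within the scatter). All three stay within the scatter. For the measured compounds named here, none of the measured compounds carries chlorine, however, so the entering group itself is untested. No step beyond the scatter is therefore expected in this assay. The expected step is a 1.0-fold lower number from compound 3 to compound 4 (0.01 log units; within the scatter). Compound 4 is estimated at 60000 nM, with an expected range from 25000 nM to 100000 nM.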

Compound 4, half-maximal cytotoxic concentration: 17000 nM
Compound 4: middle estimate off by 3.5-fold (0.55 log units), on the high side; measured number below the stated range.
By their numbers in this assay, from the lowest: compound 4; then compounds 3, 1 and 2 (each within the scatter of the next).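

With this assay as the measure, the group on this carbonyl carbon can move the number beyond the scatter, which the nitrophenyl and difluorophenyl compounds alone did not show. Bringing in 3,4-dichlorophenyl gives a 3.6-fold lower number from compound 3 to compound 4 (0.56 log units; beyond the scatter) and also a 5.9-fold lower number from compound 2 to compound 4 (0.77 log units; beyond the scatter) and also a 5.9-fold lower number from compound 1 to compound 4 (0.77 log units; beyond the scatter) so compound 4 is the least tolerated of the four. Nothing available explains this step.

As far as these compounds go, whether the step goes with chlorine itself, with the number of chlorine atoms or with where they sit on the ring stays open. A phenyl ring carrying one chlorine, two bromine atoms or two methyl groups on this same carbonyl carbon would help to separate these possibilities.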